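The compounds below may be only part of what the source reports. "The series", "measured", "known", "first", "only" and "open" are said of these compounds alone.

Measured compounds:
compound 1 `CC(C)NC(=N)c1ccc2oc(-c3ccc(OCCCCCOc4ccccc4)cc3)cc2c1` with 20500 nM
compound 2 `c1ccc(OCCCCCOc2ccc(-c3cc4cc(C5=NCCN5)ccc4o3)cc2)cc1` with 900 nM
compound 3 `CC(C)NC(=N)c1ccc2cc(-c3ccc(OCCCCOc4ccccc4)cc3)oc2c1` with 15900 nM

All three were tested in an ADME assay on L6 cells (Rattus norvegicus) for cytotoxicity, read by resazurin assay, with a stated time of 70 h; a lower number here means a stronger inhibitor, a higher number a weaker inhibitor. Compound 1 and compound 2 share a core and differ in a single group: a group of 5 heavy atoms (3 carbon, 2 nitrogen; one five-membered non-aromatic ring with 2 hetero atoms) in place of a group of 6 heavy atoms (4 carbon, 2 nitrogen; no ring), on an aromatic carbon. That change gave a 23-fold lower number from compound 1 to compound 2 (1.36 log units; beyond the scatter), so compound 2 gives the much lower number of the pair. Compound 3 carries the same group as compound 1 on a different core; the difference between the two cores is not broken down here. In this assay compound 3 gives 15900 nM, which sits close to the number for compound 1, within the usual scatter.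

Compound 4 `c1ccc(OCCCCOc2ccc(-c3cc4ccc(C5=NCCN5)cc4o3)cc2)cc1` has not yet been measured. It is made from compound 3 by a group of 5 heavy atoms (3 carbon, 2 nitrogen; one five-membered non-aromatic ring with 2 hetero atoms) in place of a group of 6 heavy atoms (4 carbon, 2 nitrogen; no ring), on an aromatic carbon, and the place is described in the same words as for the change from compound 1 to compound 2, so it is the same change made on the other core. If it behaves the same way, the step is expected to be about as large as the earlier one. Compound 4 is therefore expected to show a 20-fold lower number from compound 3 to compound 4 (1.30 log units; beyond the scatter), resting on the size of the step from compound 1 to compound 2 and on compound 3 giving 15900 nM. Compound 4 is estimated at 800 nM, between 300 nM and 2500 nM.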

Compound 4, half-maximal inhibitory concentration: 16900 nM
Beside the measured number, compound 4's estimate is 21-fold (1.32 log units) below it, outside the stated range (above it).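

In this assay, the same swap of the open-chain group for the five-membered ring, made on the second core, gave a 1.1-fold higher number from compound 3 to compound 4 (0.03 log units; within the scatter), so this time the swap made no difference beyond the usual scatter. Set beside the earlier step, the effect of the change did not carry over from one core to the other: the same change on two cores in this assay, a 23-fold lower number (1.36 log units; beyond the scatter) from compound 1 to compound 2 and a 1.1-fold higher number (0.03 log units; within the scatter) from compound 3 to compound 4, 24-fold (1.38 log units) apart, beyond the scatter of two such steps. Among these compounds, this shows that the large step seen on the first core cannot be assumed for every core, but with only two pairs it does not show which difference between the cores matters, or how the change would behave on any further core.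

The compounds shown leave open whether a plain amine or a six-membered ring at the same place would follow the first core's pattern or the second's. They also leave open whether the size of the step would stay the same if the chain in either core were made longer.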